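Sulfation of amide-bearing sugar cores, thymidine incorporation series

This account rests on a few compounds, and the source may have more. Where it says the series, first, only, none or still open, it means among the compounds named here.

Compound 1 `C=CCCC(=O)N[C@H]1[C@@H](OCCc2ccccc2)O[C@H](CO)[C@@H](O)[C@@H]1O` and compound 2 `C=CCCC(=O)N[C@H]1[C@@H](OCCCCCCCCCCCCCCCC)O[C@H](CO)[C@@H](O)[C@@H]1O` share an amide-bearing sugar core; the difference between their cores is not broken down here. In a functional assay on U-373MG ATCC cells (Homo sapiens), read by thymidine incorporation (a higher number here means a weaker inhibitor, a lower number a stronger inhibitor), compound 1 gives > 50 uM, which is a limit of the assay and not a number. In this assay compound 2 gives > 50 uM, likewise a limit. Compound 3 `C=CCCC(=O)N[C@H]1[C@@H](OCCCCCCCCCCCCCCCC)O[C@H](CO)[C@@H](O)[C@@H]1OS(=O)(=O)O` carries sulfo in place of hydrogen on an oxygen on a saturated carbon; in this assay compound 3 gives 33 uM, which amounts to an at least 1.5-fold lower number from compound 2 to compound 3 (0.18 log units; that floor lies within the scatter), read against (the limit of > 50 uM in this assay, at which 2 of the 3 values shown sit). Compound 4 `C=CCCC(=O)N[C@H]1[C@@H](OCCc2ccccc2)O[C@H](COS(=O)(=O)O)[C@@H](O)[C@@H]1O` carries the same kind of change, (sulfo in place of hydrogen on an oxygen on a saturated carbon), the saturated carbon having a saturated chain carbon as its other neighbour rather than a saturated ring carbon. The step expected is an at least 1.1-fold lower number from compound 1 to compound 4 (0.04 log units; that floor lies within the scatter), resting on the modest at least 1.5-fold lower number from compound 2 to compound 3 (0.18 log units; that floor lies within the scatter). Compound 4 is expected to give about 45 uM, within 15 uM to 120 uM.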

Compound 4, concentration for 50% inhibition: > 50 uM
Compound 4 gave a limit, no number; the forecaster's own chance of this, stated with the estimate: 55%; middle value at least 1.1-fold (0.04 log units) from the limit.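

Compound 1 and compound 4 both give a limit and not a number, so no step can be read between them: the limit of > 50 uM in this assay, at which 3 of the 4 values shown sit.

From the compounds shown here alone, what the change from hydroxymethyl to (sulfooxy)methyl does to inhibition on this core remains open.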